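Swapping the aryl amide halogen on a triazole-linked chromene ester

The source may report more compounds than this note shows. Statements on the series, on what has been measured and on what is new or still open speak of the compounds shown alone.

Compound 1 (`CCOC(=O)C1=Cc2ccccc2OC1(OCc1cn(CC(=O)Nc2cccc(Cl)c2)nn1)C(F)(F)F`) carries a 3-chlorophenyl group on an amide-type nitrogen next to a carbonyl carbon, with the amide tied through a methylene to a triazole that hangs from the shared core. Among the measured compounds shown here, in a functional assay on MCF7 cells (Homo sapiens) for inhibition, read by MTT assay, with a stated time of 24 h (a lower number here means a stronger inhibitor, a higher number a weaker inhibitor), compound 1 gives 11600 nM, which is the only plain number measured. Compound 2 (`CCOC(=O)C1=Cc2ccccc2OC1(OCc1cc(-c2ccc(OC)cc2)no1)C(F)(F)F`) replaces the triazole arm with an isoxazole bearing a 4-methoxyphenyl group. For compound 2 this assay returns only a limit, > 150000 nM, and the limit of > 150000 nM in this assay, at which 1 of the 2 values shown sits, marks that one of the two results sits there. For the measured compounds named here, no pair of measured compounds differs in a single place, so no measured step is available.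

Compound 3 (`CCOC(=O)C1=Cc2ccccc2OC1(OCc1cn(CC(=O)Nc2ccccc2F)nn1)C(F)(F)F`) differs from compound 1 by 2-fluorophenyl in place of 3-chlorophenyl on an amide-type nitrogen; the group leaving and the group entering each hold one halogen on a phenyl ring. With one number and one limit, the step is expected to be small, in either direction or none beyond the scatter. Compound 3 is estimated at 15000 nM, with a range from 5000 nM to 50000 nM. The estimate a 1.3-fold higher number from compound 1 to compound 3 (0.11 log units; within the scatter) is expected to stay within the scatter of repeats.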

Compound 3, half-maximal inhibitory concentration: 42100 nM
Compound 3: the middle estimate sits 2.8-fold (0.45 log units) below what was measured, within the range that was stated.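

In this assay, the aryl group on an amide-type nitrogen proves able to shift the result, even when one halogen-bearing phenyl ring replaces another: 2-fluorophenyl in place of 3-chlorophenyl gives a 3.6-fold higher number from compound 1 to compound 3 (0.56 log units; beyond the scatter). Among the compounds shown here, this modest step lies beyond the scatter and is the only single-place comparison, so it shows that the triazole arm and the shared core do not alone set the value and that compound 1 is the stronger inhibitor of this pair. The measurements show the size and direction of the step, but nothing shown accounts for it.

The change replaces chlorine with fluorine and also alters the name-given place of the halogen on the phenyl ring, and the compounds shown cannot separate these two parts of the step. Going by these compounds, whether a plain phenyl group with no halogen, or a phenyl ring bearing an amine or a carboxylic acid, would move the number in either direction remains open.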